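The source may hold more compounds than are shown below. What is called first, only, known or untested is meant among the compounds shown, and "the series" means these compounds.

Of the compounds shown here, two have been measured in a functional assay on ileum for antagonist activity at muscarinic acetylcholine receptor M3 (Cavia porcellus); on this read-out lower numbers stand for stronger inhibition and higher numbers for weaker inhibition. Compound 1 `O=C(CN1CCC(N2CCCC2)CC1)C(O)(c1ccccc1)C1CCCCC1` gives 349 nM. Compound 2 `O=C(CN1CCN(C/C=C\c2ccccc2)CC1)C(O)(c1ccccc1)C1CCC1` gives 9.92 nM, the lowest of the two numbers, and its gap to compound 1 lies beyond the scatter. Compound 3 `CC(C)=CCN1CCN(CC(=O)C(O)(c2ccccc2)C2CCC2)CC1` is not yet measured; it differs from compound 2 by 2-methylprop-1-en-1-yl in place of 2-phenylethenyl on a saturated chain carbon bound to an amine nitrogen in a ring. Within the data shown here, no measured pair shows this change, so its size is unknown. The step of a 4.0-fold higher number from compound 2 to compound 3 (0.61 log units; beyond the scatter) is expected to be a moderate increase, beyond the scatter. Compound 3 is therefore estimated at 40 nM, within a range from 10 nM to 160 nM.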

Compound 3, antagonist equilibrium constant: 22 nM
Compound 3: the middle estimate sits 1.8-fold (0.26 log units) above what was measured; low and high end bracket the measured number.
By their numbers in this assay, from the lowest: compound 2; then compound 3; then compound 1.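

Replacing 2-phenylethenyl with 2-methylprop-1-en-1-yl on a saturated chain carbon bound to an amine nitrogen in a ring gives a 2.2-fold higher number from compound 2 to compound 3 (0.35 log units; beyond the scatter) as a modest loss of inhibition. The aromatic ring is therefore not essential here: compound 3, whose new group has no ring and fewer heavy atoms, still gives 22 nM as its value. Nothing available explains this step.

Open, as far as these compounds go, is whether the double bond matters, which a saturated 3-methylbutyl group in place of 3-methylbut-2-en-1-yl would test. A benzyl group would likewise test the aromatic ring on a shorter chain.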